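This account rests on a few compounds, and the source may have more. Where it says the series, first, only, none or still open, it means among the compounds named here.

Working notes on a short chalcone set measured in a functional assay on HCT-116 cells (Homo sapiens) for cytotoxicity, read by resazurin assay, with a stated time of 48 h; on this read-out lower numbers stand for an effect already at smaller amounts and higher numbers for an effect only at larger amounts of compound. Compound 1 `O=C(/C=C/c1ccc([N+](=O)[O-])cc1)c1ccc(O)c(O)c1` gives 5800 nM in this assay. Compound 2 `Nc1ccc(C(=O)/C=C/c2ccccc2)cc1` gives 27000 nM in this assay, the higher of the two numbers, and it stands apart from compound 1 by a gap beyond the usual scatter. Within the data shown here, no single-point step connects these two, so only their two values are compared here.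

The next member, compound 3 `O=C(/C=C/c1ccccc1)c1ccc(NC(=O)c2ccccc2)cc1`, differs from compound 2 by benzoyl in place of hydrogen on a nitrogen on an aromatic ring. Among the measured compounds shown here, no measured pair in this set shows such a change, so the size of the step from compound 2 to compound 3 in this assay cannot be read off; it is expected to be small, pointing toward lower numbers if anywhere, and perhaps within the scatter. Compound 3 is therefore estimated at 14000 nM in this assay, with a range of 4000 nM to 45000 nM, which amounts to an expected step of a 1.9-fold lower number from compound 2 to compound 3 (0.29 log units; within the scatter).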

Compound 3, half-maximal effective concentration: 17000 nM
Estimate against measurement, compound 3: 1.2-fold (0.08 log units) below, within the range that was stated.
By their numbers in this assay, from the lowest: compound 1; then compounds 3 and 2 (each within the scatter of the next).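

In this assay the series now holds its first single-point step, and it concerns benzoyl in place of hydrogen on a nitrogen on an aromatic ring: a 1.6-fold lower number from compound 2 to compound 3 (0.20 log units; within the scatter) is what this change amounts to. This nitrogen therefore accepts benzoyl, with its 8 heavy atoms and six-membered aromatic ring, without a shift beyond the usual scatter, although this rests on one pair alone. No measurement offered here bears on the reason for this result.

On these data alone, whether a smaller group on the same nitrogen, such as acetyl or methyl, would also leave the value within the scatter remains open. So does the effect of a benzoyl carrying a carboxylic acid or an amine on its ring.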